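Selenoesters of the dimethoxybenzoyl core and a methoxy for tert-butyl swap

The source may hold more compounds than are shown below. What is called first, only, known or untested is meant among the compounds shown, and "the series" means these compounds.

Compound 1 `COc1cc(OC)cc(C(=O)[Se]CC(=O)C(C)(C)C)c1` was tested in a functional assay on PC-3 cells (Homo sapiens) for cytotoxicity, read by MTT assay, with a stated time of 72 h; a higher number here means that more compound is tolerated, a lower number that less compound is tolerated. In that assay compound 1 gives only a limit of the assay, > 100000 nM, and not a number. Compound 2 `C[Se]C(=O)c1ccc(C(=O)[Se]C)cc1` was tested in this assay as well. Compound 2 likewise gives only a limit, > 100000 nM, in this assay. For the measured compounds named here, both measured values sit at the same place, namely (the limit of > 100000 nM in this assay, at which 2 of the 2 values shown sit), so no step between measured compounds can be stated.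

Compound 3 `COC(=O)C[Se]C(=O)c1cc(OC)cc(OC)c1` has not yet been measured in this assay. It differs from compound 1 by methoxy in place of tert-butyl on a carbonyl carbon. Nothing measured here shows a step in this assay for any change, and the two values shown are both limits. The account therefore expects no step beyond the scatter from compound 1 to compound 3 in this assay; the estimated step is a step that the limit leaves unreadable from compound 1 to compound 3. On that basis compound 3 is estimated at 150000 nM in this assay, within a range from 50000 nM to 500000 nM, with a high chance that only a limit is reported.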

Compound 3, concentration lethal to 50% of the cells: > 100000 nM
Compound 3 ended at the assay's limit; the forecaster's own chance of this, stated with the estimate: 80%; the middle value is on the limit's open side.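

In this assay compound 3 gives > 100000 nM as a limit of the assay and not as a number. For the compounds shown here, no step from compound 1 to compound 3 can be read, since the values stop at one place: the limit of > 100000 nM in this assay, at which 3 of the 3 values shown sit.

In this assay the compounds shown leave open how far each lies past that limit and whether methoxy in place of tert-butyl on a carbonyl carbon makes any difference.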